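The source may hold more compounds than are shown below. What is called first, only, known or untested is meant among the compounds shown, and "the series" means these compounds.

Measured so far:
Compound 1, `COc1cc(N(Cc2ccc(F)cc2)C(=O)CSc2nc3ccccc3s2)cc(OC)c1OC`: > 80000 nM
Compound 2, `COc1ccc(CN(C(=O)CSc2nc3ccccc3s2)c2cc(OC)c(OC)c(OC)c2)cc1N`: 84 nM
Compound 3, `COc1ccc(CN(C(=O)CSc2nc3cc(Cl)ccc3s2)c2cc(OC)c(OC)c(OC)c2)cc1O`: 85 nM

In a functional assay on MGC-803 cells (Homo sapiens) for antiproliferative activity, read by MTT assay, with a stated time of 48 h (on this read-out higher numbers stand for weaker inhibition and lower numbers for stronger inhibition), compound 1 gives only a limit, > 80000 nM, which is the limit (the limit of > 80000 nM in this assay, at which 1 of the 3 values shown sits). Compound 2 gives 84 nM in this assay, the lowest of the two numbers shown; compound 3, which carries a hydroxy in place of the amino and a chlorine on the shared core, gives 85 nM, and the two values lie within the scatter of each other, so no order between them can be claimed.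

The account now turns from compound 2 to compound 4, `COc1ccc(CN(C(=O)CSc2nc3ccccc3s2)c2cc(OC)c(OC)c(OC)c2)cc1`, not yet measured in this assay. The change is hydrogen in place of amino on an aromatic carbon. Among the compounds with values here, only one measured step touches this position: an at least 950-fold lower number from compound 1 to compound 2 (2.97 log units; beyond the scatter). That step, however, exchanges the whole 4-fluorophenyl for the 3-amino-4-methoxyphenyl, so it does not isolate the amino. Within the data shown here, compound 3 shows that a hydroxy at that place gives much the same number as the amino, but no measured pair removes the group altogether.

A modest loss is therefore expected: a 3.6-fold higher number from compound 2 to compound 4 (0.55 log units; beyond the scatter). Compound 4 is estimated at 300 nM, with a range from 80 nM to 3000 nM.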

Compound 4, half-maximal inhibitory concentration: 163 nM
Beside the measured number, compound 4's estimate is 1.8-fold (0.26 log units) above it, within the range that was stated.
By their numbers in this assay, from the lowest: compounds 2, 3 and 4 (each within the scatter of the next). At a limit, above all of these: compound 1.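

Removing the amino leaves the number in this assay within the scatter, with a 1.9-fold higher number from compound 2 to compound 4 (0.29 log units; within the scatter), so among the compounds shown the amino on this aromatic carbon is not required for a value of this order, and no hydrogen-bond donor need stand at this place. The large step seen earlier therefore cannot be credited to the amino, since a single exchange at the other aromatic carbon of this ring already gives an at least 490-fold lower number from compound 1 to compound 4 (2.69 log units; beyond the scatter), with methoxy in place of fluoro. The size of that step is bounded on one side only, since compound 1 stands at a limit and not at a number: the limit of > 80000 nM in this assay, at which 1 of the 4 values shown sits.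

The compounds shown leave open whether methoxy itself is what counts at that carbon, or whether a chloro, a methyl or an ethoxy there would serve as well. They also leave open whether a dimethylamino or a fluoro in the place of the amino would stay within the scatter of compound 4, and compound 3 cannot settle this, as it differs from compound 2 in two places.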